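A few compounds are considered here, and "the series" means these few. Any claim that something is new, unique, unknown or untested is made for them only; others in the source may bear on it.

Of the compounds shown here, three have been measured in a functional assay, with a stated time of 20 min, tested at 50 uM; on this read-out lower numbers stand for a weaker effect and higher numbers for a stronger effect at the one concentration tested. Compound 1 `COc1cc(/C=C/C(=O)C2=C(/C=C/c3ccc(O)c(OC)c3)NC(=S)NC2c2ccccc2)ccc1O` gives 48%. Compound 2 `COc1cc(/C=C/C(=O)C2=C(/C=C/c3ccc(O)c(OC)c3)NC(=S)NC2c2ccc(C)cc2)ccc1O`, which carries methyl in place of hydrogen on an aromatic carbon, gives 62%, a change of a number 14 percentage points higher from compound 1 to compound 2 (beyond the scatter). Compound 3 `COc1cc(/C=C/C(=O)C2=C(/C=C/c3ccc(O)c(OC)c3)NC(=S)NC2c2ccc(N(C)C)cc2)ccc1O` gives 89.5%, the highest of the three numbers, with compound 2 nearest and compound 1 furthest; the corresponding steps are a number 41.5 percentage points higher from compound 1 to compound 3 (beyond the scatter) and a number 27.5 percentage points higher from compound 2 to compound 3 (beyond the scatter), both beyond the scatter.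

Compound 4 `COc1cc(/C=C/C(=O)C2=C(/C=C/c3ccc(O)c(OC)c3)NC(=S)NC2c2ccccc2Cl)ccc1O` has not yet been measured. It differs from compound 3 by 2-chlorophenyl in place of 4-(dimethylamino)phenyl on a saturated ring carbon. Both measured steps that bear on this change point the same way: adding dimethylamino raised the read-out in this assay by a large margin from compound 1 and by a modest one from compound 2, so its removal is expected to lower the read-out. Within the data shown here, no measured compound carries 2-chlorophenyl, so what that group contributes on its own is unknown; the nearest guide is compound 1, whose value of 48% sits where the unsubstituted phenyl analogue lands. The expected step is therefore a number 39.5 percentage points lower from compound 3 to compound 4 (beyond the scatter), a fall beyond the scatter. For compound 4 the estimated activity is 50%, within a range from 32% to 68%.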

Compound 4, a percentage reported as activity, at one concentration (the size of the read-out at that concentration, not a potency): 60%
Compound 4: the middle estimate sits 10 percentage points below what was measured, within the range that was stated.
By their numbers in this assay, from the lowest: compound 1; then compounds 4 and 2 (each within the scatter of the next); then compound 3.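

In this assay the gain over plain phenyl on the saturated ring carbon is not confined to 4-methylphenyl and 4-(dimethylamino)phenyl, since 2-chlorophenyl also stands clear of it (a number 12 percentage points higher from compound 1 to compound 4 (beyond the scatter)). The 2-chlorophenyl and 4-methylphenyl groups cannot be told apart on this read-out (a number 2 percentage points lower from compound 2 to compound 4 (within the scatter)), whereas 4-(dimethylamino)phenyl remains well separated from 2-chlorophenyl (a number 29.5 percentage points lower from compound 3 to compound 4 (beyond the scatter)), so of the four groups shown at this position it alone gives a read-out beyond the scatter of all the others. Nothing measured here accounts for why the read-out follows these groups.

From the compounds shown here alone, it remains open whether a chlorine atom would give the same read-out in the place that the dimethylamino group holds in compound 3, so the contribution of chloro cannot yet be separated from where it sits on the ring. Going by these compounds, it is equally open whether the high read-out of compound 3 is particular to dimethylamino or would also appear with a primary amine or a methoxy group in that place, and a single tested concentration leaves the potency of all four compounds unknown.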